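This account rests on a few compounds, and the source may have more. Where it says the series, first, only, none or still open, it means among the compounds named here.

Working notes on the series. Compound 1 `Cc1ccccc1-c1nc(CN2CCC(C(=O)NCCCN3[C@H](C)CCC[C@@H]3C)CC2)c(C)o1` and compound 2 `Cc1oc(-c2c(Br)cccc2Br)nc1CN1CCC(C(=O)NCCCN2C[C@H](C)C[C@H](C)C2)CC1` share a core and differ in the aryl group attached to it. In a physicochemical assay for solubility, in phosphate buffer, measured as kinetic solubility, at pH 7.4 (a lower number here means a less soluble compound, a higher number a more soluble compound), compound 1 gives only a limit, > 69 ug/mL, not a number. Going by the values given here, compound 2 gives 62.4 ug/mL in this assay, the only number so far. The other recorded value, that of compound 1, is a limit (the limit of > 69 ug/mL in this assay, at which 1 of the 2 values shown sits). Compound 3 `COc1cccc(F)c1-c1nc(CN2CCC(C(=O)NCCCN3C[C@H](C)C[C@H](C)C3)CC2)c(C)o1` is not yet measured; it departs from compound 2 as follows: 2-fluoro-6-methoxyphenyl in place of 2,6-dibromophenyl on an aromatic carbon. Among the compounds with values here, no measured step covers such a change, so the expected step of a 1.2-fold higher number from compound 2 to compound 3 (0.08 log units; within the scatter) is small, toward higher solubility, possibly within the scatter. Compound 3 is estimated at 75 ug/mL, with a range from 40 ug/mL to 150 ug/mL.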

Compound 3, solubility: > 74 ug/mL
Compound 3 was reported as a limit; the forecaster's own chance of this, stated with the estimate: 50%; the middle value lies beyond the limit too.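

In this assay the change at this aromatic carbon gives an at least 1.1-fold higher number from compound 2 to compound 3 (0.07 log units; that floor lies within the scatter) as the first step measured at this position. The result for compound 3 is a limit, not a number: the limit of > 74 ug/mL in this assay, at which 1 of the 3 values shown sits.
The step is therefore known only as a floor, and that floor does not separate the two aryl groups beyond the scatter.

As far as these compounds go, the true size of the step remains open. Also open, from the compounds shown here alone, is how a pyridine ring or an aryl group bearing a carboxylic acid would read in this assay at this position.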